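A few compounds are considered here, and "the series" means these few. Any claim that something is new, unique, unknown or untested is made for them only; others in the source may bear on it.

Compound 1 `S=C(NCc1ccccc1)N1CCN(c2ncccn2)CC1`: in a functional assay on RAW264.7 cells (Mus musculus) for inhibition, read by Griess assay, with a stated time of 24 h (on this read-out lower numbers stand for stronger inhibition and higher numbers for weaker inhibition), compound 1 gives >= 200000 nM, which is a limit of the assay rather than a number.
Compound 2 `O=C(C1CCCO1)N1CCN(C(=S)NCc2ccccc2)CC1`: in this assay compound 2 gives >= 200000 nM, likewise a limit.

Going by the values given here, compound 2 therefore stands at the edge of what this assay can report, and the only measured step, a step that the two limits leave unreadable from compound 1 to compound 2, cannot be read, since both of its ends are limits; this is summed up by the limit of >= 200000 nM in this assay, at which 2 of the 2 values shown sit. The next compound, compound 3 `CCCCN1CCN(C(=S)NCc2ccccc2)CC1`, differs from compound 2 by butyl in place of (oxolan-2-yl)carbonyl on an amine nitrogen in a ring. Among the compounds with values here, no measured step covers a change of this kind, so nothing in the numbers points to a shift in either direction. Given that both measured values sit at the limit, the expectation for the step of a number no higher from compound 2 to compound 3 (the limit leaves the size open) is simply that it stays within the scatter, with no gain in inhibition. Compound 3 is accordingly estimated at 200000 nM, within a range from 60000 nM to 400000 nM, most likely reported again as a limit.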

Compound 3, half-maximal inhibitory concentration: >= 200000 nM
Compound 3: no number, only a limit; the forecaster's own chance of this, stated with the estimate: 70%; the middle value sits exactly at the limit.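

In this assay compound 3 gives >= 200000 nM, again a limit. The steps among compound 1, compound 2 and compound 3 therefore cannot be read: the limit of >= 200000 nM in this assay, at which 3 of the 3 values shown sit. The compounds shown leave open whether any group on the amine nitrogen in the ring gives a measurable inhibition.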